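Thiophosphate serine amides: the enantiomer of compound 2

A few compounds are considered here, and "the series" means these few. Any claim that something is new, unique, unknown or untested is made for them only; others in the source may bear on it.

Measured so far:
compound 1, `CCCCCCCCNC(=O)[C@@H](COP(=O)(O)O)NC(=O)CCCCCCC`: 935 nM
compound 2, `CCCCCCCCNC(=O)[C@H](COP(O)(O)=S)NC(=O)CCCCCCC`: 251 nM

Compound 2 has the lowest number of the two in an assay on RH7777 cells with lysophosphatidic acid receptor 3 (Homo sapiens) as the target; on this read-out lower numbers stand for stronger inhibition and higher numbers for weaker inhibition; compound 1 lies beyond the scatter above it. Compound 3, `CCCCCCCCNC(=O)[C@@H](COP(O)(O)=S)NC(=O)CCCCCCC`, is the next step: the two compounds have the same atoms and bonds and differ only in configuration as drawn: 1 of 1 stereo elements differ; a stereocentre at a saturated chain carbon is drawn S in compound 2 and R in compound 3. Among the compounds with values here, no comparable step between measured compounds is available, so the size and direction of the change are uncertain; a shift beyond the scatter toward weaker inhibition is expected, but with a wide range. Compound 3 is therefore estimated at 630 nM, between 150 nM and 2500 nM, which would mean a step of a 2.5-fold higher number from compound 2 to compound 3 (0.40 log units; beyond the scatter).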

Compound 3, half-maximal inhibitory concentration: 302 nM
Compound 3: the middle estimate sits 2.1-fold (0.32 log units) above what was measured; the range from low to high includes it.
By their numbers in this assay, from the lowest: compounds 2 and 3 (each within the scatter of the next); then compound 1.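

Moving the stereocentre from S to R gives a 1.2-fold higher number from compound 2 to compound 3 (0.08 log units; within the scatter) in this assay, so the drawn configuration at this carbon does not separate the two thiophosphates on this read-out. This comparison isolates a single variable: the fact that compounds 2 and 3 differ only in the configuration as drawn. With compound 3, the thiophosphate can also be set against the phosphate at matching configuration, which gives a 3.1-fold lower number from compound 1 to compound 3 (0.49 log units; beyond the scatter).

The compounds shown leave open whether configuration at this carbon matters for the phosphate as well. They also leave open how a carboxylic acid in place of the thiophosphate, or a longer chain on either amide, would read in this assay.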